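Triphenyl core: a longer acid-bearing chain

This account rests on a few compounds, and the source may have more. Where it says the series, first, only, none or still open, it means among the compounds named here.

Values in a functional assay for inhibition, with Homo sapiens as the target; a lower number here means a stronger inhibitor, a higher number a weaker inhibitor:
- compound 1 `O=C(O)CCCCCCn1nc(-c2ccccc2)c(-c2ccccc2)c1-c1ccccc1`: 22400 nM
- compound 2 `O=C(O)CCCCCCCCn1cc(-c2ccccc2)cn1`: > 105000 nM (a limit)
- compound 3 `O=C(O)CCCCCCn1cc(-c2ccccc2)c(-c2ccccc2)n1`: > 92000 nM (a limit)

For the measured compounds named here, compound 1 gives 22400 nM, the only true number in this small set. Compound 2 reached only a limit, > 105000 nM. Compound 3 also reached only a limit, > 92000 nM.

The next compound is compound 4 `O=C(O)CSCCCCCCn1nc(-c2ccccc2)c(-c2ccccc2)c1-c1ccccc1`, and the change is (carboxymethyl)sulfanyl in place of carboxy on a saturated chain carbon, six bonds along the chain from an aromatic nitrogen. Going by the values given here, no measured compound carries this group, so no measured step speaks to the change directly.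

Among the compounds with values here, the one measured step is an at least 4.1-fold higher number from compound 1 to compound 3 (0.61 log units; beyond the scatter), with hydrogen in place of phenyl on an aromatic carbon. It lies beyond the scatter, but it concerns the core and not the chain. Its bearing is indirect: compound 4 keeps the core of compound 1 intact, so a measurable number is more likely than a limit.

In this assay a modest move to a lower number is expected, though with little confidence in the direction. The expected step is a 2.2-fold lower number from compound 1 to compound 4 (0.35 log units; beyond the scatter). For compound 4 the estimated value is 10000 nM, with an expected range of 1800 nM to 50000 nM.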

Compound 4, half-maximal inhibitory concentration: 870 nM
Beside the measured number, compound 4's estimate is 11-fold (1.06 log units) above it; measured number outside the range, below it.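

In this assay, the far end of the chain proves to be a sensitive position: (carboxymethyl)sulfanyl in place of carboxy, on a saturated chain carbon, six bonds along the chain from an aromatic nitrogen, gives a 26-fold lower number from compound 1 to compound 4 (1.41 log units; beyond the scatter). For the compounds shown here, the only step readable before this one, an at least 4.1-fold higher number from compound 1 to compound 3 (0.61 log units; beyond the scatter), concerned a phenyl on the core and said nothing about the chain. Here the core of compound 1 stays intact, so the change at the chain end alone accounts for this large step, but nothing measured here says what underlies it.

The change brings in the sulfur and the added carboxymethyl together, so the compounds shown do not tell which of the two carries the step; an all-carbon chain of matching length, or an oxygen in place of the sulfur, would separate them. Also open, as far as these compounds go, is whether the terminal carboxylic acid of compound 4 is needed at all, which a methyl ester or a primary amide at that chain end would test, and whether the same (carboxymethyl)sulfanyl chain would lower the number on the core of compound 3.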